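Three alkyne caps measured, a fourth estimated

This account rests on a few compounds, and the source may have more. Where it says the series, first, only, none or still open, it means among the compounds named here.

Compound 1, `Cc1ccc(C#Cc2ccc(C(=O)N[C@H](C)C(C)(C)O)nc2)cc1`, in a functional assay on HEK293 cells for positive allosteric modulation of metabotropic glutamate receptor 5 (Rattus norvegicus), read by fluorescence and calcium flux (on this read-out higher numbers stand for larger maximal responses and lower numbers for smaller maximal responses), gives 63.1%.
Compound 2, `Cc1nc(C#Cc2ccc(C(=O)N[C@H](C)C(C)(C)O)nc2)cs1`, in this assay gives 66.6%.
Compound 3, `C[C@@H](NC(=O)c1ccc(C#CC2CC2)cn1)C(C)(C)O`, in this assay gives 63.4%.

Compound 3 stands second highest of the three, yet within the scatter of both neighbours: a number 0.3 percentage points higher from compound 1 to compound 3 (within the scatter) and a number 3.2 percentage points lower from compound 2 to compound 3 (within the scatter). Compound 4, `C[C@@H](NC(=O)c1ccc(C#Cc2ccc(F)cn2)cn1)C(C)(C)O`, differs from compound 3 by 5-fluoropyridin-2-yl in place of cyclopropyl on a triple-bonded carbon. Going by the values given here, the steps that bear on this site, a number 3.5 percentage points higher from compound 1 to compound 2 (within the scatter) and a number 0.3 percentage points higher from compound 1 to compound 3 (within the scatter), show that exchanging the cap on the triple-bonded carbon has so far left the maximal response unchanged, whether an aromatic ring or a small carbocycle sits there. Accordingly, no step beyond the scatter is expected in this assay, and for compound 4 the expected step is a number 0.6 percentage points higher from compound 3 to compound 4 (within the scatter). Compound 4 is estimated to give 64%, between 52% and 76%.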

Compound 4, largest response reached (reported as efficacy), in percent of the reference or control that the assay uses: 64.6%
Compound 4: middle estimate off by 0.6 percentage points, on the low side, and the stated range covers the measured number.
By their numbers in this assay, from the lowest: compounds 1, 3, 4 and 2 (each within the scatter of the next).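

Unlike the earlier caps, 5-fluoropyridin-2-yl carries fluorine, yet in this assay it stays level with all three of them: a number 1.2 percentage points higher from compound 3 to compound 4 (within the scatter), a number 2 percentage points lower from compound 2 to compound 4 (within the scatter) and a number 1.5 percentage points higher from compound 1 to compound 4 (within the scatter). Among these four compounds, none goes against the flat pattern at the triple-bonded carbon, which now includes a six-membered aromatic ring with a hetero atom. No measurement shown explains this flatness. Going by these compounds, it remains open whether a cap bearing an amine or a carboxylic acid, or a longer chain, would move the maximal response beyond the scatter.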